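Working notes: compound 3 to compound 4

The compounds below may be only part of what the source reports. "The series", "measured", "known", "first", "only" and "open" are said of these compounds alone.

Values so far in a physicochemical assay for lipophilicity, using the shake flask method, in phosphate buffer, measured as octanol-water partition, with a stated time of 24 h, at pH 7.4, tested at 100 uM; a lower number here means a more polar compound, a higher number a more lipophilic compound
Compound 1 `CCCOc1cc(C)c(-c2cccc(COc3ccc(S(=O)(=O)CC(=O)O)cc3)c2)c(C)c1` result: 3.58
Compound 2 `Cc1cc(OCC(C)C)cc(C)c1-c1cccc(COc2ccc(S(=O)(=O)CC(=O)O)cc2)c1` result: 3.94
Compound 3 `O=C(O)CS(=O)(=O)c1ccc(OCc2cccc(-c3ccccc3F)c2)cc1` result: "not determined" (no result reported)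

Among the compounds with values here, compound 3 gives no number to start from, and it has no measured step to any other compound. The next compound to be measured is compound 4 `CCOc1ccc(-c2cccc(COc3ccc(S(=O)(=O)CC(=O)O)cc3)c2)c(Cl)c1`. The change is 2-chloro-4-ethoxyphenyl in place of 2-fluorophenyl on an aromatic carbon, meta to a large group: 2-chloro-4-ethoxyphenyl in place of 2-fluorophenyl on an aromatic carbon.

Within the data shown here, only one measured step exists, and it bears on this change only loosely. That step, a number 0.36 log units higher from compound 1 to compound 2 (beyond the scatter), is modest and is methyl in place of hydrogen on a saturated chain carbon. The swap here is a different and larger one, made on an aromatic carbon. Without a number for compound 3, no size or direction of step in this assay can be stated, so the estimate is anchored on levels instead. Compound 1 (3.58) and compound 2 (3.94) share the core and also carry an ether chain on the aromatic group, so they are the closest guides. A value near the lower of these two is expected, with a wide range given the thin data. Compound 4 is estimated at 3.4 (2.9 to 3.9).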

Compound 4, distribution coefficient: 3.12
Beside the measured number, compound 4's estimate is 0.28 log units above it; the measured number falls inside the stated range.
By their numbers in this assay, from the lowest: compound 4; then compound 1; then compound 2.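

No new step can be read in this assay: compound 3 gives no number, so the pair of compound 3 and compound 4 yields no comparison. The compounds shown leave open how far, and in which direction, 2-chloro-4-ethoxyphenyl in place of 2-fluorophenyl moves the value. No measured evidence bears on a cause for the value of compound 4.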